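The source may hold more compounds than are shown below. What is called first, only, known or untested is meant among the compounds shown, and "the series" means these compounds.

Measured in an assay on C6 glioma cells for displacement of a labelled ligand from sodium- and chloride-dependent glycine transporter 1 (Rattus norvegicus), read by scintillation counting, with stated times of 30 min and 10 min; on this read-out higher numbers stand for weaker inhibition and lower numbers for stronger inhibition:

- compound 1 `CCc1nnc(-c2ccc(-c3ccccc3)cc2)n1-c1cccc(N)c1C` gives 320 nM
- compound 2 `CCc1nnc(-c2ccc(-c3ccccc3)cc2)n1-c1cccc(CO)c1C` gives 250 nM
- compound 3 `CCc1nnc(-c2ccc(-c3ccccc3)cc2)n1-c1cccc(COC)c1C` gives 2400 nM

Compound 3 stands highest of the three numbers in this assay: a 7.5-fold higher number from compound 1 to compound 3 (0.88 log units; beyond the scatter) and a 9.6-fold higher number from compound 2 to compound 3 (0.98 log units; beyond the scatter), whereas a 1.3-fold lower number from compound 1 to compound 2 (0.11 log units; within the scatter). Compound 4 `CCc1nnc(-c2ccc(-c3ccccc3)cc2)n1-c1cccc(CN(C)C)c1C` differs from compound 3 by dimethylamino in place of methoxy on a saturated chain carbon bound to an aromatic carbon. The step that bears on this is a 9.6-fold higher number from compound 2 to compound 3 (0.98 log units; beyond the scatter), where a hydrogen on the oxygen was exchanged for methyl; compound 4, like compound 3, has no hydrogen-bond donor at that chain carbon. Within the data shown here, no measured pair exchanges oxygen for nitrogen on that chain, so the expected step is a 1.6-fold lower number from compound 3 to compound 4 (0.20 log units; within the scatter), not beyond the scatter. Compound 4 is estimated at 1500 nM, within a range from 400 nM to 6000 nM.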

Compound 4, half-maximal inhibitory concentration: 29000 nM
Estimate against measurement, compound 4: 19-fold (1.29 log units) below, outside the stated range (above it).
By their numbers in this assay, from the lowest: compounds 2 and 1 (each within the scatter of the next); then compound 3; then compound 4.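

Compound 3 and compound 4 count the same hydrogen-bond donors and acceptors at the saturated chain carbon bound to an aromatic carbon, yet the exchange of methoxy for dimethylamino gives a 12-fold higher number from compound 3 to compound 4 (1.08 log units; beyond the scatter), so those counts do not settle the value at this position. Set against the other two compounds, the same group gives a 120-fold higher number from compound 2 to compound 4 (2.06 log units; beyond the scatter) and a 91-fold higher number from compound 1 to compound 4 (1.96 log units; beyond the scatter). Nothing measured here accounts for this change.

As far as these compounds go, whether a smaller aminomethyl group or a carboxylic acid at this position would stand nearer compound 1 and compound 2 or nearer compound 4 remains open.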